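The source may hold more compounds than are shown below. What is called first, only, known or untested is meant among the compounds shown, and "the series" means these compounds.

Measured in a functional assay on A549 cells (Homo sapiens) for cytotoxicity, read by MTT assay, with a stated time of 48 h; a lower number here means a stronger inhibitor, a higher number a weaker inhibitor:
- compound 1 `COc1ccc(-c2c[nH]c(=O)n2-c2cc(OC)c(OC)c(OC)c2)cc1[N+](=O)[O-]`: > 50000 nM (a limit, not a number)
- compound 2 `COc1ccc(-c2c[nH]c(=O)n2-c2cc(OC)c(OC)c(OC)c2)cc1N`: > 50000 nM (a limit, not a number)
- compound 3 `COc1cc(NC(=O)n2cc(-c3ccc(O)cc3)n(-c3cc(OC)c(OC)c(OC)c3)c2=O)cc(OC)c1OC`: 2500 nM

For the measured compounds named here, compound 3 is the only compound with a true number. All that stands beside it is the limit of > 50000 nM in this assay, at which 2 of the 3 values shown sit.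

The next compound is compound 4 `COc1ccc(-c2cn(C(=O)Nc3cc(OC)c(OC)c(OC)c3)c(=O)n2-c2cc(OC)c(OC)c(OC)c2)cc1O`, and the change from compound 3 is 3-hydroxy-4-methoxyphenyl in place of 4-hydroxyphenyl on an aromatic carbon. Going by the values given here, the rest of the structure stays the same, so the step concerns only this aryl group.

Among the compounds with values here, the one measured step is a step that the two limits leave unreadable from compound 1 to compound 2. Within the data shown here, it gives no size that could be carried over, and no measured step covers this exchange directly. Among the measured compounds shown here, the only anchor is therefore compound 3 at 2500 nM.

In this assay no shift beyond the usual scatter is expected, and no firm direction can be claimed, although a slight gain is pencilled in. The expected step is a 1.4-fold lower number from compound 3 to compound 4 (0.14 log units; within the scatter). The estimate for compound 4 is 1800 nM, with an expected range of 250 nM to 12000 nM.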

Compound 4, half-maximal inhibitory concentration: > 50000 nM
Compound 4 gave a limit, no number (the forecaster's own chance of this, stated with the estimate: 8%); at least 27-fold (1.44 log units) between middle value and limit.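

At this position in this assay, the aryl group matters: the exchange gives an at least 20-fold higher number from compound 3 to compound 4 (1.30 log units; beyond the scatter), and the upper end of that step is a limit, not a number. For the compounds shown here, the earlier compounds offered no readable step, so this is the first sign that a change to this aryl group alone, with the rest of the structure held fixed, can move the read-out beyond the scatter. Going by these compounds alone, compound 3 remains the only compound with a true number, and everything else sits at one shared end of the scale: the limit of > 50000 nM in this assay, at which 3 of the 4 values shown sit.

The exchange alters both the hydroxy placement and the methoxy content of the ring at once, and the two are not separated here. Going by these compounds, how a 3-hydroxyphenyl or a 4-methoxyphenyl group would read at this place stays open.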